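The source may hold more compounds than are shown below. What is called first, only, known or untested is meant among the compounds shown, and "the series" means these compounds.

Measured compounds:
- compound 1 `O=C1O[C@@H](CN2CCC(O)CC2)CN1c1ccc(-n2cc(-c3ccccn3)cn2)c(F)c1`; in an ADME assay on HEK293-A cells (Homo sapiens) for cytotoxicity, read by MTT assay, with a stated time of 48 h (a higher number here means a weaker inhibitor, a lower number a stronger inhibitor), compound 1 gives > 400 ug/mL, a limit of the assay.
- compound 2 `O=C1CCC(=O)N1C[C@H]1CN(c2ccc(-n3cc(-c4ccccn4)cn3)c(F)c2)C(=O)O1`; compound 2 gives > 400 ug/mL, again a limit of the assay.
- compound 3 `O=C1CNC(=O)N1C[C@H]1CN(c2ccc(-n3cc(-c4ccccn4)cn3)c(F)c2)C(=O)O1`; compound 3 gives > 400 ug/mL, also a limit of the assay.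

Compound 3 therefore stands at the assay ceiling, and so do the other two measured compounds: the limit of > 400 ug/mL in this assay, at which 3 of the 3 values shown sit. Each of the three measured steps is shown as unreadable, since both ends sit at the limit: a step that the two limits leave unreadable from compound 1 to compound 2, a step that the two limits leave unreadable from compound 1 to compound 3 and a step that the two limits leave unreadable from compound 2 to compound 3. Among the compounds with values here, nothing so far gives a numerical size for any change at this position.

Within the data shown here, the new compound, compound 4 `O=C1O[C@@H](Cn2ccnn2)CN1c1ccc(-n2cc(-c3ccccn3)cn2)c(F)c1`, differs from compound 3 at the same position as the earlier steps: 1H-1,2,3-triazol-1-yl in place of 2,5-dioxoimidazolidin-1-yl on a saturated chain carbon bound to a saturated ring carbon. All three measured steps bear on it in the sense that they alter the same substituent on the same chain carbon, but all of them are unreadable, so no direction or size can be carried over. The only available read-out is that three different groups at this position all sit at the limit.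

Accordingly, the expected step that the limit leaves unreadable from compound 3 to compound 4 is none beyond the scatter, and compound 4 is most likely to be returned as a limit as well. Compound 4 is estimated at 500 ug/mL, with a range from 250 ug/mL to 1000 ug/mL.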

Compound 4, half-maximal inhibitory concentration: 225 ug/mL
Compound 4: middle estimate off by 2.2-fold (0.35 log units), on the high side; measured number below the stated range.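

In this assay, within the data shown here, the 1H-1,2,3-triazol-1-yl group on the saturated chain carbon gives compound 4 the only value at this position that is a number and not a limit, and the change from 2,5-dioxoimidazolidin-1-yl reads as an at least 1.7-fold lower number from compound 3 to compound 4 (0.24 log units; that floor lies within the scatter). The same replacement reads as an at least 1.7-fold lower number from compound 2 to compound 4 (0.24 log units; that floor lies within the scatter) against 2,5-dioxopyrrolidin-1-yl and as an at least 1.7-fold lower number from compound 1 to compound 4 (0.24 log units; that floor lies within the scatter) against 4-hydroxypiperidin-1-yl. All three steps are floors, so the position now has one number to work from but no step shown beyond the scatter, and the ceiling still dominates the series: the limit of > 400 ug/mL in this assay, at which 3 of the 4 values shown sit.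

From the compounds shown here alone, the steps among compound 1, compound 2 and compound 3 still cannot be read, so the order of those groups and their true distance from compound 4 remain open. Also open, going by these compounds, is whether the lower number belongs to the 1H-1,2,3-triazol-1-yl group alone or would also appear with 1H-1,2,4-triazol-1-yl, 1H-imidazol-1-yl or a simple amine on the same saturated chain carbon.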